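The source may report more compounds than this note shows. Statements on the series, on what has been measured and on what is new or still open speak of the compounds shown alone.

Going by the values given here, in a functional assay on MDA-MB-231 cells (Homo sapiens) for cytotoxicity, read by MTT assay, with a stated time of 72 h (on this read-out higher numbers stand for weaker inhibition and lower numbers for stronger inhibition), compound 1 `CN(C)CCCNc1nc(-c2ccc(NC(=O)Nc3ccccc3F)cc2)nc2ccsc12` gives 660 nM, the lower of the two numbers measured so far. Among the compounds with values here, compound 2 `CN(C)CCCNc1nc(-c2ccc(NC(=O)Nc3ccc(Cl)cc3Cl)cc2)nc2ccsc12` gives 1860 nM, and the only measured step, a 2.8-fold higher number from compound 1 to compound 2 (0.45 log units; beyond the scatter), concerns the group on the amide-type nitrogen. Compound 3 `CCN(CC)CCCNc1nc(-c2ccc(NC(=O)Nc3ccccc3F)cc2)nc2ccsc12` differs from compound 1 by diethylamino in place of dimethylamino on a saturated chain carbon, three bonds along the chain from a nitrogen on an aromatic ring. That measured step touches a different part of the molecule, so nothing measured bears directly on this change. The step is therefore expected to be no change at the digits printed from compound 1 to compound 3 (within the scatter), with no shift beyond the scatter. Compound 3 is estimated at 660 nM, with a range from 330 nM to 1320 nM.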

Compound 3, half-maximal inhibitory concentration: 860 nM
Compound 3: middle estimate off by 1.3-fold (0.11 log units), on the low side, within the range that was stated.
By their numbers in this assay, from the lowest: compounds 1 and 3 (each within the scatter of the next); then compound 2.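

Putting diethylamino in place of dimethylamino on the saturated chain gives a 1.3-fold higher number from compound 1 to compound 3 (0.11 log units; within the scatter) in this assay, so on this read-out the two amines cannot be told apart at this place. Going by these compounds alone, the earlier step concerned only the group on the amide-type nitrogen, and this is the first measured change at the amine end of the chain. Nothing measured gives a reason for this result. Still open, on these data alone, is whether a ring amine such as morpholine, or a longer chain, would keep the number in this range. Also open, as far as these compounds go, is whether the same swap would read alike with 2,4-dichlorophenyl on the amide-type nitrogen.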